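The compounds below may be only part of what the source reports. "The series", "measured", "known", "first", "only" and "open" are said of these compounds alone.

Measured so far:
compound 1, `COc1ccc(-c2cc(/C=C/C(=O)c3ccc(N)cc3)[nH]n2)cc1`: 8%
compound 2, `COc1cc(-c2cc(/C=C/C(=O)c3ccc(N)cc3)[nH]n2)cc(OC)c1OC`: -19%

Both numbers come from a functional assay on NCI-H23 cells (Homo sapiens) for cytotoxicity, read by sulforhodamine B assay, with a stated time of 48 h, tested at 10 uM; a higher number here means a weaker effect of the compound at the concentration tested, a lower number a stronger effect. Compound 2 stands lowest of the two; compound 1 sits higher by a margin beyond the usual scatter, so of the two, compound 2 shows the stronger effect at the concentration tested. Neither number lies far from zero, and both compounds read as weak in this assay.

Compound 3, `COc1ccc(C(=O)/C=C/c2cc(-c3cc(OC)c(OC)c(OC)c3)n[nH]2)cc1`, is not yet measured. It differs from compound 2 in one place: methoxy in place of amino on an aromatic carbon. Read one bond further out, 4-aminophenyl becomes 4-methoxyphenyl. Going by the values given here, no measured pair shows this change, so no step size can be read off. The two measured compounds only show that a change on the other aryl group shifted the number by an amount beyond the scatter.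

For compound 3 a small upward step in this assay is expected, weaker or no different beyond the scatter, with little confidence either way. Compound 3 is expected to give -5%, with a range from -30% to 25%. This estimate implies a step of a number 14 percentage points higher from compound 2 to compound 3 (beyond the scatter).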

Compound 3, a percentage reported as activity, at one concentration (the size of the read-out at that concentration, not a potency): 2%
Beside the measured number, compound 3's estimate is 7 percentage points below it, within the range that was stated.
By their numbers in this assay, from the lowest: compound 2; then compounds 3 and 1 (each within the scatter of the next).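

In this assay, going by these compounds alone, methoxy in place of amino on the aromatic carbon para to a large group gives a number 21 percentage points higher from compound 2 to compound 3 (beyond the scatter) and is the only measured change at this position, with the rest of compound 2 held fixed. The 4-aminophenyl to 4-methoxyphenyl exchange therefore has a modest effect that can be told from the scatter, and its direction is toward a weaker effect at the concentration tested. The change also takes the read-out from a negative number for compound 2 at -19% to one close to zero for compound 3 at 2% in the same assay, so this position is not silent, though the series remains weak at this single concentration.

Within the data shown here, this rests on one pair, so it is open whether the same exchange gives a step of similar size when the other aryl group is the one carried by compound 1. Also open, from the compounds shown here alone, is how a hydroxyl, a dimethylamino group, a carboxylic acid or a longer alkoxy chain at this position would read against amino and methoxy.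

No measurement at hand bears on why the number moves with this exchange.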